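This account rests on a few compounds, and the source may have more. Where it says the series, first, only, none or still open, it means among the compounds named here.

Working notes on the series. Compound 1 `Cc1c(C(=O)c2ccc(CN(C)C)cc2)oc2cc(-c3ccccc3)cc(O)c12`, compound 2 `Cc1c(C(=O)c2cnc3ccccc3c2)oc2cc(-c3ccccc3)cc(O)c12` and compound 3 `Cc1c(C(=O)Cc2ccccc2)oc2cc(-c3ccccc3)cc(O)c12` share one core and differ only in the group on the carbonyl carbon. In a functional assay on WI-38 VA13 cells (Homo sapiens) for cytotoxicity (on this read-out lower numbers stand for an effect already at smaller amounts and higher numbers for an effect only at larger amounts of compound), compound 1 gives > 4 ug/mL, which is a limit of the assay and not a number. Compound 2 gives > 4 ug/mL in this assay, again a limit. Compound 3 gives > 4 ug/mL in this assay, also a limit. Among the compounds with values here, compound 3 thus stands where every measured compound stands, at the limit of > 4 ug/mL in this assay, at which 3 of the 3 values shown sit, and no step between measured compounds can be read, since none of them yields a number.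

Compound 4 `COc1ccccc1C(=O)c1oc2cc(-c3ccccc3)cc(O)c2c1C` is not yet measured. It differs from compound 3 in one place: 2-methoxyphenyl in place of benzyl on a carbonyl carbon. Within the data shown here, with all three measured values sitting at the same limit, the data give no direction for a step in this assay; the expectation is that compound 4 behaves like its relatives and shows no effect within the tested range. The step from compound 3 to compound 4 in this assay is expected to be a step that the limit leaves unreadable from compound 3 to compound 4, none beyond the scatter. Compound 4 is expected at 10 ug/mL in this assay, within 3 ug/mL to 40 ug/mL, most likely reported again as a limit rather than a number.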

Compound 4, half-maximal effective concentration: 0.09 ug/mL
The estimate for compound 4 lay 110-fold (2.05 log units) above the measured number; the whole stated range lies above it.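

In this assay the group on the carbonyl carbon proves able to move the read-out: 2-methoxyphenyl in place of benzyl gives an at least 44-fold lower number from compound 3 to compound 4 (1.64 log units; beyond the scatter). Before this result the series showed only one outcome, so no group at this position could be told from another: the limit of > 4 ug/mL in this assay, at which 3 of the 4 values shown sit. The change itself is small in what can be counted, with 8 heavy atoms entering for 7 and 1 hydrogen-bond acceptor entering for 0, and compound 1 and compound 2 show that an aromatic group on the carbonyl carbon does not by itself carry the effect, since both remain at the limit of this assay.

What the compounds shown leave open is which part of 2-methoxyphenyl matters, the methoxy group or the directly attached benzene ring, a question that plain phenyl on the carbonyl carbon would address. Equally open, from the compounds shown here alone, is how far the methoxy group tolerates change, for instance to 2-hydroxyphenyl or 2-ethoxyphenyl, and whether the result holds for anything beyond this single compound.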